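Urea to thiourea exchange on the glycosyl enone series

The source may report more compounds than this note shows. Statements on the series, on what has been measured and on what is new or still open speak of the compounds shown alone.

The shared core is a sugar-bearing enone joined to an aromatic ring that carries a urea. Compound 1 `O=C(/C=C/c1cccc(NC(=O)Nc2ccccc2)c1)C[C@@H]1O[C@H](CO)[C@@H](O)[C@H](O)[C@H]1O` in an ADME assay on Vero cells (Chlorocebus sabaeus) for cytotoxicity, read by resazurin assay, with a stated time of 2 days (a lower number here means that less compound is tolerated, a higher number that more compound is tolerated), gives 373000 nM. Compound 2 `O=C(/C=C/c1cccc(NC(=O)Nc2ccccc2)c1)C[C@@H]1O[C@H](CO)[C@@H](O)[C@H](O)[C@@H]1O` in this assay gives "not determined" (no result reported); the two are related by the fact that compounds 1 and 2 differ only in the configuration as drawn, and nothing else separates them, so compound 2 stands on no number of its own and the value of compound 1 is the only anchor in the series.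

Compound 3 `O=C(/C=C/c1cccc(NC(=S)Nc2ccccc2)c1)C[C@@H]1O[C@H](CO)[C@@H](O)[C@H](O)[C@@H]1O` differs from compound 2 by a group of 9 heavy atoms (7 carbon, 1 nitrogen, 1 sulfur; one six-membered aromatic ring of carbon only) in place of a group of 9 heavy atoms (7 carbon, 1 nitrogen, 1 oxygen; one six-membered aromatic ring of carbon only), on a nitrogen on an aromatic ring. Within the data shown here, no measured step in this assay exists between any two compounds, so the size of such an exchange cannot be read from the series itself. An exchange that keeps the count of heavy atoms, donors and acceptors unchanged is expected to shift the half-maximal cytotoxic concentration little, most likely within the scatter or slightly toward less compound tolerated. For compound 3 in this assay a half-maximal cytotoxic concentration of 250000 nM is estimated, within a range of 80000 nM to 600000 nM.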

Compound 3, half-maximal cytotoxic concentration: 336000 nM
Compound 3: middle estimate off by 1.3-fold (0.13 log units), on the low side; the range from low to high includes it.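

No new step can be read from compound 3 in this assay: its only partner differing in one place, compound 2, has no number there. Open remain the size of the phenylcarbamoyl exchange on the half-maximal cytotoxic concentration and the effect of configuration, the single difference in the other pair: the fact that compounds 1 and 2 differ only in the configuration as drawn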